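The source may report more compounds than this note shows. Statements on the series, on what has been measured and on what is new or still open speak of the compounds shown alone.

Series notes. Compound 1 `COc1ccc2c(c1)[n+]([O-])nc(NC1CCC1)[n+]2[O-]` is measured in an ADME assay on Vero cells (Chlorocebus sabaeus) for cytotoxicity, read by CellTiter-Glo, with a stated time of 72 h (on this read-out higher numbers stand for lower toxicity in this test and lower numbers for higher toxicity in this test), where compound 1 gives 9.8 ug/mL. Compound 2 `COc1ccc2c(c1)[n+]([O-])nc(N[C@@H]1C[C@H]3CC[C@@H]1C3)[n+]2[O-]` carries a group of 7 heavy atoms (7 carbon; 2 five-membered non-aromatic rings of carbon only) in place of a group of 4 heavy atoms (4 carbon; one four-membered non-aromatic ring of carbon only), on a nitrogen on an aromatic ring. For compound 2 this assay returns only a limit, > 50 ug/mL. The change gives an at least 5.1-fold higher number from compound 1 to compound 2 (0.70 log units; beyond the scatter), and the step can be stated only as a bound because the value of compound 2 sits at the limit of > 50 ug/mL in this assay, at which 2 of the 3 values shown sit.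

Compound 3 `COc1cc2c(cc1C)[n+]([O-])nc(NC1CCC1)[n+]2[O-]` rests on a different core from compound 1; the difference between the two cores is not broken down here. For compound 3 this assay again returns only a limit, > 50 ug/mL.

Compound 4 `COc1cc2c(cc1C)[n+]([O-])nc(N[C@@H]1C[C@H]3CC[C@@H]1C3)[n+]2[O-]` stands to compound 3 as compound 2 stands to compound 1: a group of 7 heavy atoms (7 carbon; 2 five-membered non-aromatic rings of carbon only) in place of a group of 4 heavy atoms (4 carbon; one four-membered non-aromatic ring of carbon only), on a nitrogen on an aromatic ring, the same change, the two place descriptions reading alike word for word. Compound 4 has not yet been measured in this assay. The step from compound 3 to compound 4 is expected to be a step that the limit leaves unreadable from compound 3 to compound 4, resting on the same change having produced an at least 5.1-fold higher number from compound 1 to compound 2 (0.70 log units; beyond the scatter). Since compound 3 already sits at a limit, little downward movement is expected. Compound 4 is therefore estimated at 80 ug/mL, most likely to be reported again only as a limit.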

Compound 4, half-maximal cytotoxic concentration: > 50 ug/mL
Compound 4 was reported as a limit; the forecaster's own chance of this, stated with the estimate: 85%; the middle value lies beyond the limit too.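

In this assay compound 3 and compound 4 are both reported only as limits, so no step can be read between them, because the values sit at a shared ceiling: the limit of > 50 ug/mL in this assay, at which 3 of the 4 values shown sit.

The compounds shown leave open whether replacing cyclobutyl with the larger two-ring group changes the read-out on the core of compound 3 as it does on the core of compound 1.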